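A few compounds are considered here, and "the series" means these few. Any claim that something is new, unique, unknown or untested is made for them only; others in the source may bear on it.

In a functional assay on HepG2 cells (Homo sapiens) for cytotoxicity, with a stated time of 72 h (a higher number here means that more compound is needed for the effect, a lower number that less compound is needed), compound 1 `C=C[C@](C)(CCCC(C)C)CCc1ccc(O)cc1` gives > 52000 nM, which is a limit and not a number. Compound 2 `C=C[C@@](C)(/C=C/c1ccc(O)c(/C=C/C(N)=O)c1)CCC=C(C)C` gives > 52000 nM, also a limit. Compound 3 `COc1ccc(/C=C/[C@@](C)(/C=C/c2ccc(O)c(C=O)c2)CCC=C(C)C)cc1` gives > 26000 nM, again only a limit, so its position in the series has no measured number. Compound 4 `COc1ccc(/C=C/[C@@](C)(/C=C/c2ccc(O)c(/C=C/C(=O)OCc3ccccc3)c2)CCC=C(C)C)cc1` carries 2-(benzyloxycarbonyl)ethenyl in place of formyl on an aromatic carbon, ortho to a hydroxy group (2-(benzyloxycarbonyl)ethenyl in place of formyl on an aromatic carbon). Among the measured compounds shown here, no measured step between compounds is available to size this change. The expected step in this assay is therefore none beyond the scatter, with no direction favoured: a number no higher from compound 3 to compound 4 (the limit leaves the size open). For compound 4 the estimate is 26000 nM, with an expected range of 11000 nM to 52000 nM.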

Compound 4, half-maximal effective concentration: > 26000 nM
Compound 4: only a limit was reported; the forecaster's own chance of this, stated with the estimate: 70%; the middle value lies on the limit itself.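

Compound 3 and compound 4 are both reported only as limits in this assay, so the step from formyl to 2-(benzyloxycarbonyl)ethenyl cannot be read. The compounds shown leave open what concentration, if any, gives the half-maximal effect.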